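Swapping Chloro for Nitro: Three Measured, One Expected

The compounds below may be only part of what the source reports. "The series", "measured", "known", "first", "only" and "open" are said of these compounds alone.

Three compounds have so far been measured in a functional assay on MCF7 cells (Homo sapiens) for inhibition, read by sulforhodamine B assay, with a stated time of 48 h; on this read-out lower numbers stand for stronger inhibition of growth and higher numbers for weaker inhibition of growth:

Compound 1, `CC1=CC[C@H](C(C)(C)NC(=S)N/N=C/c2ccccc2Cl)CC1`: compound 1 gives 98300 nM.
Compound 2, `CC1=CC[C@H](C(C)(C)NC(=S)N/N=C/c2cccc(Cl)c2)CC1`: compound 2 gives 61000 nM.
Compound 3, `CC1=CC[C@H](C(C)(C)NC(=S)N/N=C/c2ccccc2[N+](=O)[O-])CC1`: compound 3 gives 94700 nM.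

Compound 2 differs from compound 1 in how the same atoms are joined: 3-chlorophenyl in place of 2-chlorophenyl on a carbon with a double bond to nitrogen. That rearrangement gave a 1.6-fold lower number from compound 1 to compound 2 (0.21 log units; within the scatter). Compound 3 arises from compound 1 by nitro in place of chloro on an aromatic carbon, and this exchange gave a 1.0-fold lower number from compound 1 to compound 3 (0.02 log units; within the scatter). All three numbers lie within the scatter of one another, so no order among them is claimed.

Compound 4, `CC1=CC[C@H](C(C)(C)NC(=S)N/N=C/c2cccc([N+](=O)[O-])c2)CC1`, is not yet measured. It arises from compound 2 by nitro in place of chloro on an aromatic carbon. This is the same kind of change as that from compound 1 to compound 3, but the place is not identical: in compound 3 the nitro stands ortho to a large group, whereas in compound 4 it stands meta to a large group. Because compound 3 showed a 1.0-fold lower number from compound 1 to compound 3 (0.02 log units; within the scatter), compound 4 is expected to show a step of about a 1.0-fold lower number from compound 2 to compound 4 (0.01 log units; within the scatter). Compound 4 is thus estimated at 60000 nM, expected to fall between 30000 nM and 120000 nM. Whether the place of the nitro matters cannot be told from these compounds alone.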

Compound 4, concentration for total growth inhibition: > 100000 nM
Compound 4: no number, only a limit (the forecaster's own chance of this, stated with the estimate: 15%); at least 1.6-fold (0.22 log units) between middle value and limit.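

The value of compound 4 in this assay is a limit of the assay and not a number: the limit of > 100000 nM in this assay, at which 1 of the 4 values shown sits. On the core of compound 2, nitro in place of chloro gave an at least 1.6-fold higher number from compound 2 to compound 4 (0.21 log units; that floor lies within the scatter), and the true size of this step may be small or large. The exchange is therefore not shown to carry over unchanged from one core to the other, nor is it shown to behave differently on the two: the same change on two cores in this assay, a 1.0-fold lower number (0.02 log units; within the scatter) from compound 1 to compound 3 and an at least 1.6-fold higher number (0.21 log units; that floor lies within the scatter) from compound 2 to compound 4; the limit leaves it open whether they differ.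

The compounds shown leave open how large the step from chloro to nitro really is on the core of compound 2, and whether it would look the same on a third core. They also do not tell how an amine or a carboxylic acid would compare with chloro and nitro on the same aromatic carbon.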